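Replacing 4-(difluoromethoxy)phenyl in compound 3

A few compounds are considered here, and "the series" means these few. Any claim that something is new, unique, unknown or untested is made for them only; others in the source may bear on it.

In a functional assay on PANC-1 cells (Homo sapiens), read by microscopy, crystal violet staining and transwell migration, with a stated time of 18 h, in the presence of a further agent that is not named here (a lower number here means a stronger inhibitor, a higher number a weaker inhibitor), compound 1 `COc1ccc(-c2nc(C)nn2-c2cccc(C(=O)NCCCOc3ccccc3)c2)cc1` gives 3120 nM, compound 2 `CCc1nc(-c2ccc(OC)cc2)n(-c2cccc(C(=O)NCCCCc3ccccc3)c2)n1` gives 140 nM and compound 3 `CCc1nc(-c2ccc(OC(F)F)cc2)n(-c2cccc(C(=O)NCCCCc3ccccc3)c2)n1` gives 830 nM. Compound 3 thus holds the second highest of the three numbers. The next structure, compound 4 `CCc1nc(-c2ccc(OC)nc2)n(-c2cccc(C(=O)NCCCCc3ccccc3)c2)n1`, has 6-methoxypyridin-3-yl in place of 4-(difluoromethoxy)phenyl on an aromatic carbon.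

Within the data shown here, one measured step bears on this change. It is a 5.9-fold higher number from compound 2 to compound 3 (0.77 log units; beyond the scatter), a modest rise beyond the scatter, made by difluoromethyl in place of methyl on an oxygen on an aromatic ring. The new group again carries a methoxy rather than a difluoromethoxy, so part of that rise may be undone. Among the measured compounds shown here, no measured step shows what a six-membered aromatic ring with a hetero atom does here, which limits confidence. In this assay the expected change is therefore a modest one towards a lower number, an estimated 2.1-fold lower number from compound 3 to compound 4 (0.32 log units; beyond the scatter). Compound 4 is estimated at 400 nM, with an expected range of 120 nM to 1400 nM.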

Compound 4, half-maximal inhibitory concentration: 810 nM
Beside the measured number, compound 4's estimate is 2.0-fold (0.31 log units) below it, within the range that was stated.
By their numbers in this assay, from the lowest: compound 2; then compounds 4 and 3 (each within the scatter of the next); then compound 1.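

In this assay, the step for 6-methoxypyridin-3-yl in place of 4-(difluoromethoxy)phenyl is a 1.0-fold lower number from compound 3 to compound 4 (0.01 log units; within the scatter), so restoring the methoxy did not by itself bring the number back towards that of compound 2. Set against 4-methoxyphenyl, the new group gives a 5.8-fold higher number from compound 2 to compound 4 (0.76 log units; beyond the scatter), which shows that this position responds to a change in the ring itself, with the methoxy kept, and not only to a change on the oxygen. Nothing measured here explains this loss. The compounds shown leave open whether a pyridine ring carrying an amine or a nitrile instead of the methoxy would behave in the same way. They also leave open how an ethoxy or a chlorine on the carbon-only ring would compare with the 4-methoxyphenyl of compound 2.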